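From a chlorophenyl limit to an aminophenyl question

This account rests on a few compounds, and the source may have more. Where it says the series, first, only, none or still open, it means among the compounds named here.

Compound 1 `COc1ccc(-c2nc3cccc(-c4cc(OC)c(OC)c(OC)c4)c3o2)cc1`: 3500 nM
Compound 2 `COc1cc(-c2cccc3nc(-c4cccc(Cl)c4)oc23)cc(OC)c1OC`: > 25000 nM (a limit of the assay)

Both compounds were tested in a functional assay on NCI-H460 cells (Homo sapiens) for antiproliferative activity, read by MTT assay, with a stated time of 48 h; a lower number here means a stronger inhibitor, a higher number a weaker inhibitor. Compound 2 stands at > 25000 nM, which is a limit of the assay and not a number.

The next compound to be measured is compound 3 `COc1cc(-c2cccc3nc(-c4ccc(N)cc4)oc23)cc(OC)c1OC`. It carries 4-aminophenyl in place of 3-chlorophenyl on an aromatic carbon of a five-membered aromatic ring with 1 nitrogen and 1 oxygen (4-aminophenyl in place of 3-chlorophenyl on an aromatic carbon).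

For the measured compounds named here, only one measured step bears on this change: an at least 7.1-fold higher number from compound 1 to compound 2 (0.85 log units; beyond the scatter), with 3-chlorophenyl entering in place of 4-methoxyphenyl at the same place. Compound 3 gives up that same 3-chlorophenyl, so a move back toward compound 1 at 3500 nM is expected, a step of similar size toward a lower number in this assay. This expectation rests on a single step, and 4-aminophenyl has not yet been measured on this core.

The estimated step is an at least 8.3-fold lower number from compound 2 to compound 3 (0.92 log units; beyond the scatter). For compound 3 the estimate is 3000 nM, with an expected range from 500 nM to 20000 nM.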

Compound 3, half-maximal inhibitory concentration: 310 nM
Compound 3: middle estimate off by 9.7-fold (0.99 log units), on the high side; the measured number lies below the stated range.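

Until now, changing the phenyl group at this place, on the aromatic carbon next to the ring nitrogen and next to the ring oxygen, had only been seen to raise the number in this assay; 4-aminophenyl in place of 3-chlorophenyl shows that the same place can also lower it sharply, with an at least 80-fold lower number from compound 2 to compound 3 (1.90 log units; beyond the scatter). The comparison with compound 1 is read as a full number: amino in place of methoxy on an aromatic carbon gives an 11-fold lower number from compound 1 to compound 3 (1.05 log units; beyond the scatter), so the 4-methoxyphenyl of compound 1 does not mark the best result seen at this place. Compound 2 stands at a limit of the assay, so the step from it gives only a bound: the limit of > 25000 nM in this assay, at which 1 of the 3 values shown sits.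

Going by these compounds, what remains open is whether the gain follows the amine itself or its place on the phenyl ring, since 3-chlorophenyl and 4-aminophenyl differ in both; 3-aminophenyl and 4-chlorophenyl would separate the two. Also open, on these data alone, is whether a dimethylamino group, an acetamide or a hydroxy group in place of the amine would keep the number near that of compound 3.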